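This account rests on a few compounds, and the source may have more. Where it says the series, first, only, none or still open, it means among the compounds named here.

Compound 2 `Cc1nc(N(C)C(=O)NC(=O)c2c(F)cccc2F)sc1C(=O)N/N=C/c1ccccc1Cl` gives only a limit of the assay in a functional assay on HepG2 cells (Homo sapiens) for inhibition, read by MTT assay, with a stated time of 72 h (on this read-out lower numbers stand for stronger inhibition and higher numbers for weaker inhibition), namely > 100 ug/mL. It thus sits at the limit of > 100 ug/mL in this assay, at which 2 of the 2 values shown sit. Compound 1 `CNc1nc(C)c(C(=O)N/N=C/c2cccc(C(F)(F)F)c2)s1`, built on a different core, shows the same picture in this assay with the limit > 100 ug/mL. Compound 3 `Cc1nc(N(C)C(=O)NC(=O)c2c(F)cccc2F)sc1C(=O)N/N=C/c1cccc(C(F)(F)F)c1` is compound 2 with 3-(trifluoromethyl)phenyl in place of 2-chlorophenyl on a carbon with a double bond to nitrogen. Compound 1 carries the same 3-(trifluoromethyl)phenyl group and gives only the limit > 100 ug/mL. For that reason the step that the limit leaves unreadable from compound 2 to compound 3 is expected to be none beyond the scatter. Compound 3 is therefore estimated at 150 ug/mL, within 50 ug/mL to 500 ug/mL, most likely reported again only as a limit.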

Compound 3, half-maximal inhibitory concentration: 31.6 ug/mL
Estimate against measurement, compound 3: 4.7-fold (0.68 log units) above; measured number below the stated range.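

In this assay, the group on the carbon with a double bond to nitrogen can change the result: 3-(trifluoromethyl)phenyl in place of 2-chlorophenyl gives an at least 3.1-fold lower number from compound 2 to compound 3 (0.50 log units; beyond the scatter). On this shared core, the change brings a real number out of the limit of the assay. That step is only a minimum, since compound 2 gives a limit and not a number: the limit of > 100 ug/mL in this assay, at which 2 of the 3 values shown sit.

From the compounds shown here alone, whether the lower number comes from the trifluoromethyl group arriving or the chlorine leaving stays open. An unsubstituted phenyl or a pyridine ring at this place could help separate the two.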